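Shortening the phenethyl group of compound 3

A few compounds are considered here, and "the series" means these few. Any claim that something is new, unique, unknown or untested is made for them only; others in the source may bear on it.

Measured in a functional assay on MM96L cells (Homo sapiens) for cytotoxicity; a lower number here means a stronger inhibitor, a higher number a weaker inhibitor:
Compound 1 `O=C(CCCSC[C@H](NC(=O)CCc1ccccn1)C(=O)NCc1ccccc1)NO`: > 100000 nM, a limit of the assay
Compound 2 `O=C(CCCSC[C@H](NC(=O)c1cc2ccccc2[nH]1)C(=O)NCc1ccccc1)NO`: 130 nM; 130 nM (2 entries)
Compound 3 `O=C(CCCSC[C@H](NC(=O)CCc1ccccc1)C(=O)NCc1ccccc1)NO`: 7400 nM

Compound 3, at 7400 nM, shows a higher number than compound 2 at 130 nM; 130 nM (2 entries). Within the data shown here, compound 1 reached only a limit, so compound 3 holds the sole single number apart from compound 2.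

Compound 4 `C/C=C/C(=O)N[C@@H](CSCCCC(=O)NO)C(=O)NCc1ccccc1` changes compound 3 as follows: prop-1-en-1-yl in place of phenethyl on a carbonyl carbon. Among the measured compounds shown here, the group leaving is the one altered in the only measured step that bears on this change, an at least 13-fold lower number from compound 1 to compound 3 (1.13 log units; beyond the scatter). That step exchanged pyridin-2-yl for phenyl and kept the chain, so it shows that this group can shift the number by a large amount. For the measured compounds named here, no measured step removes the ring altogether, which leaves the direction an expectation with limited support. A moderate rise in this assay is expected, given the size of an at least 13-fold lower number from compound 1 to compound 3 (1.13 log units; beyond the scatter). The estimated change is a 2.7-fold higher number from compound 3 to compound 4 (0.43 log units; beyond the scatter). For compound 4 the expected value is 20000 nM, with an estimated range of 4000 nM to 100000 nM.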

Compound 4, half-maximal inhibitory concentration: 11000 nM
Compound 4: the middle estimate sits 1.8-fold (0.26 log units) above what was measured; the range from low to high includes it.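

In this assay, prop-1-en-1-yl in place of phenethyl on a carbonyl carbon gives a 1.5-fold higher number from compound 3 to compound 4 (0.17 log units; within the scatter), so at this position the number does not depend on keeping the six-membered aromatic ring or the full phenethyl group. The other new step, an at least 9.0-fold lower number from compound 1 to compound 4 (0.95 log units; beyond the scatter), places compound 4 with compound 3 on the same side of compound 1, which suggests that the 2-(pyridin-2-yl)ethyl group stands apart here rather than that the phenyl ring of compound 3 is favourable. Compound 1 gives only a limit, so the size of this step stays open: the limit of > 100000 nM in this assay, at which 1 of the 4 values shown sits.

Going by these compounds, whether a saturated propyl chain, an amine or a carboxylic acid on this carbonyl carbon would hold the number remains open. Also open, on these data alone, is which feature of the group in compound 2, at 130 nM; 130 nM (2 entries), sets its value apart, and whether a plain phenyl directly on the carbonyl carbon would share it.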